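This account rests on a few compounds, and the source may have more. Where it says the series, first, only, none or still open, it means among the compounds named here.

Working notes on the series. Two compounds of the shared core have numbers in an assay for inhibition of lanosterol synthase (Rattus norvegicus), using microsomes, tested at 100 nM; a lower number here means less inhibition, a higher number more inhibition at the concentration tested (going by the name of the read-out). Compound 1 `O=C(N1CCN(c2ccncc2Cl)CC1)N1CCN(S(=O)(=O)c2ccc(Cl)cc2)CC1` carries a chloro on the aromatic carbon of the sulfonyl-bearing ring; in this assay compound 1 gives 87%. Compound 2 `O=C(N1CCN(c2ccncc2Cl)CC1)N1CCN(S(=O)(=O)c2ccc(Br)cc2)CC1` differs only in a bromo in place of chloro on an aromatic carbon, and in this assay compound 2 gives 100%. For the measured compounds named here, the single measured step, a number 13 percentage points higher from compound 1 to compound 2 (beyond the scatter), runs upward. Going by the values given here, on the numbers so far compound 2 stands highest of the two, with compound 1 as its only neighbour, lower by a step beyond the scatter.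

Among the compounds with values here, compound 3 `O=C(N1CCN(c2ccncc2Cl)CC1)N1CCN(S(=O)(=O)c2ccc(F)cc2)CC1` is the next member: fluoro in place of bromo on an aromatic carbon The only step that bears on this change is the halogen swap at the same aromatic carbon, a number 13 percentage points higher from compound 1 to compound 2 (beyond the scatter), a modest step upward. Compound 3 is expected to move the other way, downward from compound 2 by about a number 26 percentage points lower from compound 2 to compound 3 (beyond the scatter), because the exchange of chloro for bromo gave a number 13 percentage points higher from compound 1 to compound 2 (beyond the scatter). For compound 3 the estimate in this assay is 74%, with a range from 55% to 92%; the measured number follows.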

Compound 3, a percentage reported as inhibition, at one concentration (the size of the read-out at that concentration, not a potency): 100%
Estimate against measurement, compound 3: 26 percentage points below; the whole stated range lies below it.
By their numbers in this assay, from the lowest: compound 1; then compounds 2 and 3 (each within the scatter of the next).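

In this assay the step at this aromatic carbon shows no change with fluoro in place of bromo, no change at the digits printed from compound 2 to compound 3 (within the scatter), while fluoro in place of chloro gives a rise, a number 13 percentage points higher from compound 1 to compound 3 (beyond the scatter), so the two replacements of chloro land at the same reading. The earlier upward step from chloro to bromo therefore does not extend into an order running along the halogens: compound 1 stands apart, and the 4-bromophenyl and 4-fluorophenyl members cannot be told apart, with compound 2 at 100% and compound 3 at 100% as sizes of inhibition at one concentration and not potencies. No measurement at hand bears on why the chloro member alone reads lower.

Still open, as far as these compounds go, is whether a group other than a halogen on this aromatic carbon, such as methoxy, a nitrile or an amine, would hold the reading of compound 2 and compound 3 or lower it. Also open, from the compounds shown here alone, is how compound 2 and compound 3 compare in potency, which a reading at a single concentration cannot tell.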